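A few compounds are considered here, and "the series" means these few. Any claim that something is new, unique, unknown or untested is made for them only; others in the source may bear on it.

The series shares one core, carried by compound 1 `CCCC1=C(C(=O)OCC2CCCCC2)C(c2cccc(O)c2)NC(=O)N1`, compound 2 `CC(C)C1=C(C(=O)OCC2CCCCC2)C(c2cccc(O)c2)NC(=O)N1` and compound 3 `CCC1=C(C(=O)OCC2CCCCC2)C(c2ccc(O)cc2)NC(=O)N1`. In an ADME assay on CEMx174 cells (Homo sapiens) for cytotoxicity (on this read-out lower numbers stand for higher toxicity in this test and higher numbers for lower toxicity in this test), compound 1 reaches only a limit of the assay, > 10000 nM. For compound 2 in this assay the result stands as "not determined" (no result reported). Compound 3 likewise sits at a limit in this assay, > 10000 nM, so only a limit or a range is known for it. Of the remaining two results one is also a limit and one has no number, so compound 3 cannot be placed above or below any companion; two of the three values rest at the limit of > 10000 nM in this assay, at which 2 of the 3 values shown sit.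

The step onward leads to compound 4 `CCC1=C(C(=O)OCC2CCCCC2)C(c2ccc(F)cc2)NC(=O)N1`, and the change is fluoro in place of hydroxy on an aromatic carbon. Among the measured compounds shown here, no step between measured compounds is available, so the expectation for compound 4 rests on the limit of compound 3 and on (the limit of > 10000 nM in this assay, at which 2 of the 3 values shown sit); the author expects a step that the limit leaves unreadable from compound 3 to compound 4, no shift beyond the scatter. Compound 4 is accordingly estimated at 20000 nM, within 8000 nM to 60000 nM, and most likely reported again only as a limit.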

Compound 4, half-maximal cytotoxic concentration: > 10000 nM
Compound 4: no number, only a limit; the forecaster's own chance of this, stated with the estimate: 75%; the middle value lies beyond the limit too.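

Compound 3 and compound 4 both rest at a limit in this assay, so no step can be read between them. The compounds shown leave open whether fluoro in place of hydroxy changes the read-out at all, and what any true value would be: the limit of > 10000 nM in this assay, at which 3 of the 4 values shown sit.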